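Swapping the iodo group for trifluoromethyl on compound 2

This account rests on a few compounds, and the source may have more. Where it says the series, first, only, none or still open, it means among the compounds named here.

Measured so far:
compound 1, `CC(C)(C)c1ccc(-n2nc(-c3ccc(C(F)(F)F)cc3O)nc2-c2ccccc2O)cc1`, 77.8%
compound 2, `Oc1cc(C(F)(F)F)ccc1-c1nc(-c2ccccc2O)n(-c2ccc(I)cc2)n1`, 94.4%

Among the compounds with values here, in a functional assay on PC-12 cells (Rattus norvegicus) for cytotoxicity, read by MTT assay, with stated times of 2 h and 24 h, tested at 5 uM (a lower number here means a weaker effect, a higher number a stronger effect of the compound at the concentration tested), compound 2 gives 94.4%, the higher of the two numbers recorded; compound 1, the only other compound measured, gives 77.8%, a change of a number 16.6 percentage points higher from compound 1 to compound 2 (beyond the scatter). Compound 3, `Oc1cc(C(F)(F)F)ccc1-c1nc(-c2ccccc2O)n(-c2ccc(C(F)(F)F)cc2)n1`, has not yet been measured. It differs from compound 2 in one place: trifluoromethyl in place of iodo on an aromatic carbon. Within the data shown here, the only measured step, from tert-butyl to iodo at this same place, moved this assay by a modest amount beyond the scatter, so the group at this place does matter, but no measured pair shows iodo against trifluoromethyl, so the direction of the change cannot be read from the data. Compound 3 is therefore expected to land between the two measured numbers or near compound 2, with the step from compound 2 to compound 3 estimated at a number 6.4 percentage points lower from compound 2 to compound 3 (within the scatter). For compound 3 the expected value in this assay is 88%, with a range from 72% to 100%.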

Compound 3, a percentage reported as activity, at one concentration (the size of the read-out at that concentration, not a potency): 90.5%
The estimate for compound 3 lay 2.5 percentage points below the measured number; measured number inside the range.
By their numbers in this assay, from the lowest: compound 1; then compounds 3 and 2 (each within the scatter of the next).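

In this assay, putting trifluoromethyl in place of iodo on this aromatic carbon, para to a large group, gives a number 3.9 percentage points lower from compound 2 to compound 3 (within the scatter), so the two groups cannot be told apart here even though they differ in size and atoms. Trifluoromethyl in place of tert-butyl at the same position gives a number 12.7 percentage points higher from compound 1 to compound 3 (beyond the scatter), a modest step beyond the scatter, so the earlier gap between tert-butyl and iodo is no longer a single comparison: among these three compounds, compound 1 with its tert-butyl group is the one that stands apart. Nothing available explains why these groups compare as they do.

Open is how this position responds to quite different groups, such as an amine, a carboxylic acid or a longer alkyl chain, since iodo and trifluoromethyl both count no hydrogen-bond donors or acceptors and the three groups shown give only a narrow view. On these data alone, these numbers also come from one concentration, so they show the size of the effect there rather than a potency, and whether compound 2 and compound 3 would separate at another concentration remains unknown.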